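The source may report more compounds than this note shows. Statements on the series, on what has been measured and on what is new or still open speak of the compounds shown alone.

Measured compounds in a functional assay on the whole organism (stomach) for inhibition, with Canis familiaris (Canis lupus familiaris) as the target, at a dose of 5 mg/kg by the intravenous route; on this read-out higher numbers stand for a stronger effect at the one dose given and lower numbers for a weaker effect:

- compound 1, `Cc1nc2c(OCc3ccccc3)cccn2c1CCC#N`, gives 20%
- compound 2, `CCOCc1c(C)nc2c(OCc3ccccc3)cccn12`, gives 35%
- compound 3, `Cc1nc2c(OCc3ccccc3)cccn2c1Cl`, gives 37%

Compound 2 stands second highest of the three numbers: its nearest neighbour is compound 3, and the two are within the scatter of each other (a number 2 percentage points higher from compound 2 to compound 3 (within the scatter)), while compound 1 is clearly lower (a number 15 percentage points higher from compound 1 to compound 2 (beyond the scatter)).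

The unmeasured compound 4, `COC(=O)Cc1c(C)nc2c(OCc3ccccc3)cccn12`, differs from compound 2 in one place: methoxycarbonyl in place of ethoxy on a saturated chain carbon bound to an aromatic carbon.

Among the measured compounds shown here, two measured steps bear on this position. The step from compound 1 to compound 2, ethoxy in place of cyanomethyl on the same saturated chain carbon, was a number 15 percentage points higher from compound 1 to compound 2 (beyond the scatter), a modest gain. The step from compound 2 to compound 3, where the whole ethoxymethyl chain gives way to chloro, was a number 2 percentage points higher from compound 2 to compound 3 (within the scatter), within the scatter. For the measured compounds named here, the numbers therefore move only modestly when this group is changed, and no measured step tells how a methoxycarbonyl group behaves here. Compound 4 is expected to stay close to compound 2, with a step of a number 5 percentage points lower from compound 2 to compound 4 (within the scatter), so compound 4 is estimated at 30%, within a range from 15% to 48%.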

Compound 4, a percentage reported as inhibition, in the whole organism at one dose (the size of the read-out at that dose, not a potency): 16%
The estimate for compound 4 lay 14 percentage points above the measured number; measured number inside the range.
By their numbers in this assay, from the lowest: compounds 4 and 1 (each within the scatter of the next); then compounds 2 and 3 (each within the scatter of the next).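

Putting methoxycarbonyl in place of ethoxy on the saturated chain carbon bound to an aromatic carbon costs effect, with a number 19 percentage points lower from compound 2 to compound 4 (beyond the scatter), so this position does respond to the group carried on the chain. The change from chloro to (methoxycarbonyl)methyl points the same way, with a number 21 percentage points lower from compound 3 to compound 4 (beyond the scatter), whereas methoxycarbonyl and cyanomethyl cannot be told apart, with a number 4 percentage points lower from compound 1 to compound 4 (within the scatter), so the two groups that differ most from ethoxy here give matching results. Nothing measured on these compounds offers a reason for these differences.

As far as these compounds go, it remains open how a carboxylic acid or an amide would read in place of methoxycarbonyl on this chain carbon. A longer chain ending in ethoxy is likewise an open case, as is an amine at the same place.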